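Working notes: chloro in place of methyl, compound 3

This account rests on a few compounds, and the source may have more. Where it says the series, first, only, none or still open, it means among the compounds named here.

- compound 1 `COc1ccc(N(C)c2nc(C)nc3ccccc23)cc1` gives 2 nM
- compound 2 `CSc1ccc(N(C)c2nc(C)nc3ccccc23)cc1` gives 1.3 nM

Among the measured compounds shown here, in a functional assay on HeLa cells (Homo sapiens) for cytotoxicity, read by sulforhodamine B assay (on this read-out lower numbers stand for stronger inhibition and higher numbers for weaker inhibition), compound 2 gives 1.3 nM and stands within the scatter of compound 1 , the only other measured compound: a 1.5-fold lower number from compound 1 to compound 2 (0.19 log units; within the scatter).

Compound 3 `CSc1ccc(N(C)c2nc(Cl)nc3ccccc23)cc1` is not yet measured. It keeps the methylsulfanyl of compound 2 and carries chloro in place of methyl on an aromatic carbon, between two ring nitrogen atoms: chloro in place of methyl on an aromatic carbon.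

For the measured compounds named here, the single measured step, a 1.5-fold lower number from compound 1 to compound 2 (0.19 log units; within the scatter), concerns a different place, methylsulfanyl in place of methoxy, and it stays within the scatter. Going by the values given here, no measured pair tests the methyl position, so the data do not speak to this change directly. The expectation therefore starts from compound 2 at 1.3 nM and allows only a small upward move in this assay, with a wide margin.

The estimated move is a 1.9-fold higher number from compound 2 to compound 3 (0.28 log units; within the scatter).

For compound 3 the expected value is 2.5 nM, with an estimated range of 0.8 nM to 10 nM.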

Compound 3, half-maximal inhibitory concentration: 5 nM
For compound 3 the middle estimate is 2.0-fold (0.30 log units) below the measured one; the range from low to high includes it.
By their numbers in this assay, from the lowest: compounds 2 and 1 (each within the scatter of the next); then compound 3.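

In this assay, among the compounds shown here, the position between two ring nitrogen atoms responds to substitution: a 3.8-fold higher number from compound 2 to compound 3 (0.59 log units; beyond the scatter), a modest step but one beyond the scatter, whereas the only earlier step, a 1.5-fold lower number from compound 1 to compound 2 (0.19 log units; within the scatter), concerned the other end of the molecule and stayed within it. Chloro in place of methyl on this aromatic carbon therefore costs some inhibition, yet compound 3 still gives 5 nM, so the methyl group is not indispensable for activity at this level in the series. No supporting data bear on why the step has this size.

With only methyl and chloro shown at this position, the compounds leave open whether an amine, a bare hydrogen or a longer chain such as ethyl would stay close to compound 2 or move further from it. Also open, from the compounds shown here alone, is whether the step from methyl to chloro keeps its size with methoxy in place of methylsulfanyl, and whether it holds beyond this single cell line.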